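A few compounds are considered here, and "the series" means these few. Any claim that something is new, unique, unknown or untested is made for them only; others in the source may bear on it.

Measured so far in a functional assay on DU-145 cells (Homo sapiens) for inhibition, read by trypan blue exclusion, with a stated time of 96 h; on this read-out lower numbers stand for stronger inhibition of growth and higher numbers for weaker inhibition of growth:

compound 1, `Cc1ccc(S(=O)(=O)/C(=C/c2sccc2C)C(=O)c2ccc(Br)cc2)cc1`, 25000 nM
compound 2, `O=C(/C(=C\c1ccc([N+](=O)[O-])c(O)c1)SCc1ccc(Br)cc1)c1cc(Cl)ccc1O`, 10000 nM
compound 3, `COc1cc(/C=C(/Sc2ccc(Br)cc2)C(=O)c2ccc(Br)cc2)ccc1O`, 1000 nM

Compound 2 stands second highest of the three numbers in this assay. Compound 1 gives the nearest number, and it is the higher one, a gap beyond the scatter; compound 3 is furthest away, with a lower number, also beyond the scatter. For the measured compounds named here, none of the three measured compounds differs from another in a single place, so no measured step is available as a guide.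

Compound 4, `O=C(/C(=C\c1ccc([N+](=O)[O-])c(O)c1)SCc1ccc(Br)cc1)c1ccc([N+](=O)[O-])cc1`, is not yet measured. It differs from compound 2 in one place: 4-nitrophenyl in place of 5-chloro-2-hydroxyphenyl on a carbonyl carbon.

Going by the values given here, no measured step shows what this change does. The three known compounds spread widely, but each differs from the others in several places at once, so no expectation for the size or direction of the step can be drawn from them. Pending a measurement, the step from compound 2 to compound 4 is expected to be no change at the digits printed from compound 2 to compound 4 (within the scatter), that is, none beyond the scatter, with a wide range to reflect the lack of any comparable step. Compound 4 is estimated at 10000 nM in this assay, within 3000 nM to 40000 nM.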

Compound 4, concentration for 50% growth inhibition: 1000 nM
For compound 4 the middle estimate is 10-fold (1.00 log units) above the measured one; measured number below the stated range.
By their numbers in this assay, from the lowest: compounds 3 and 4 (each within the scatter of the next); then compound 2; then compound 1.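

In this assay, the aryl group on the carbonyl carbon now has its first measured single-place step: 4-nitrophenyl in place of 5-chloro-2-hydroxyphenyl gives a 10-fold lower number from compound 2 to compound 4 (1.00 log units; beyond the scatter). For the compounds shown here, this shows that the group at this position can by itself move the growth-inhibition number beyond the scatter while the rest of compound 2 stays fixed, which the earlier compounds, each differing in several places at once, could not show. No available evidence accounts for the shift in either direction.

The change removes the chlorine and the hydroxy group and introduces the nitro group in a single exchange, so the compounds shown do not separate the contribution of each, and whether the step holds with other groups elsewhere on the core remains open. Also open, as far as these compounds go, is how an amine, a carboxylic acid or a nitrile in place of the nitro group on this ring would compare with compound 4.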